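This account rests on a few compounds, and the source may have more. Where it says the series, first, only, none or still open, it means among the compounds named here.

Working notes on the series. In an assay for inhibition of RAC-alpha serine/threonine-protein kinase (Homo sapiens), read by HTRF, with a stated time of 1 h (a higher number here means a weaker inhibitor, a lower number a stronger inhibitor), compound 1 `Cn1ncc(Cl)c1-c1cc(C(=O)N[C@H]2CNCC[C@@H]2c2ccc(C(F)(F)F)cc2)oc1Cl` gives 127 nM, and compound 2 `Cn1ncc(Cl)c1-c1cc(C(=O)NC2CNCCC2c2ccc(C(F)(F)F)cc2)oc1Cl` gives 7.2 nM; the step of an 18-fold lower number from compound 1 to compound 2 (1.25 log units; beyond the scatter) is the only measured one, and its size is set against the fact that one of compounds 1 and 2 is drawn with a defined configuration and the other without, at the place where they differ rather than against any change of atoms. Compound 3 `CC(=O)NCC[C@@H]1C[C@@H](c2ccc(F)c(F)c2)[C@H](NC(=O)c2cc(-c3c(Cl)cnn3C)c(Cl)o2)CN1` gives 2.49 nM in this assay, the lowest number of the three shown, standing apart from compound 2 and further still from compound 1.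

Compound 4 `CC(=O)OCC[C@@H]1C[C@@H](c2ccc(F)c(F)c2)[C@H](NC(=O)c2cc(-c3c(Cl)cnn3C)c(Cl)o2)CN1` follows from compound 3 by one change, (acetoxy in place of acetamido on a saturated chain carbon, two bonds along the chain from a saturated ring carbon). For the measured compounds named here, no measured step touches this part of the molecule; the single step recorded concerns the drawn configuration only, so nothing measured bears directly on the new group. The change sits on the chain far from the amide and the shared core, so the expectation is a step in this assay of no more than the usual scatter, a 1.4-fold higher number from compound 3 to compound 4 (0.15 log units; within the scatter), in either direction. Compound 4 is therefore estimated at 3.5 nM, with a range from 1.2 nM to 12 nM.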

Compound 4, half-maximal inhibitory concentration: 3.4 nM
Beside the measured number, compound 4's estimate is 1.0-fold (0.01 log units) above it, within the range that was stated.
By their numbers in this assay, from the lowest: compounds 3 and 4 (each within the scatter of the next); then compound 2; then compound 1.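

For the compounds shown here, this is the first measured step at this position: in this assay, a 1.4-fold higher number from compound 3 to compound 4 (0.14 log units; within the scatter) shows that the two compounds cannot be told apart at the 2-acetamidoethyl to 2-acetoxyethyl change. On this chain, acetamido with 1 hydrogen-bond donor and acetoxy with 0 hydrogen-bond donors therefore read alike, within the scatter, on the shared core. No evidence at hand bears on why these two groups read alike.

Still open, as far as these compounds go, is whether a hydroxyl, a primary amine or a carboxylic acid on the same saturated chain carbon, or a longer chain carrying the acetoxy group, would also read alike in this assay. Also open, from the compounds shown here alone, is whether acetoxy in place of acetamido would give the same result with another group on the saturated ring.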